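The source may report more compounds than this note shows. Statements on the series, on what has been measured and on what is new or still open speak of the compounds shown alone.

Within the data shown here, compound 2 `C#CCN(Cc1ccc2nc(C)nc(O)c2c1)c1cccc(Br)c1` gives 5300 nM in a functional assay on GC3/MTK- cells (Homo sapiens) for inhibition (on this read-out higher numbers stand for weaker inhibition and lower numbers for stronger inhibition), and stands lowest of the two numbers so far; compound 1 `C#CCN(Cc1ccc2nc(C)nc(O)c2c1)c1cccc(C(C)O)c1` gives 49000 nM in this assay, the step being a 9.2-fold lower number from compound 1 to compound 2 (0.97 log units; beyond the scatter). Compound 3 `C#CCN(Cc1ccc2nc(C)nc(O)c2c1)c1cccc(I)c1` carries the change (iodo in place of bromo on an aromatic carbon). Among the measured compounds shown here, no measured step bears directly on this halogen swap; the only step seen, from compound 1 to compound 2, concerns a different group and says nothing about iodo against bromo. For compound 3 the step of a 1.3-fold lower number from compound 2 to compound 3 (0.12 log units; within the scatter) is therefore expected to stay within the scatter. Compound 3 is estimated at 4000 nM in this assay, with a range of 1500 nM to 12000 nM.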

Compound 3, half-maximal inhibitory concentration: > 5300 nM
Compound 3: no number, only a limit; the forecaster's own chance of this, stated with the estimate: 3%; middle value at least 1.3-fold (0.12 log units) from the limit.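

Compound 3 reads only as a limit in this assay, > 5300 nM. The step to it from compound 1 cannot be read. At this position, iodo in place of bromo gives a number no lower from compound 2 to compound 3 (the limit leaves the size open), so the larger halogen brings no measurable gain in this read-out. The halogen swap therefore adds a direction but no size to what compound 1 and compound 2 showed.

Still open, from the compounds shown here alone, are where compound 3 stands relative to compound 1, and how chloro, an amine or a carboxylic acid would read at this position.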